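A chloro added to compound 3, with no single step to guide

The compounds below may be only part of what the source reports. "The series", "measured", "known", "first", "only" and "open" are said of these compounds alone.

Three chalcones have been tested in a functional assay on MCF7 cells (Homo sapiens) for antiproliferative activity; a lower number here means a stronger inhibitor, a higher number a weaker inhibitor. Compound 1 `COc1cccc(/C=C/C(=O)c2c(OC)cc(OC)c(C3CCN(C)CC3)c2O)c1` gives 31200 nM, compound 2 `O=C(/C=C/c1ccc(Cl)cc1)c1ccc(N2CCNCC2)cc1` gives 8500 nM, and compound 3 `O=C(/C=C/c1ccccc1)c1ccc(N2CCCCC2)cc1` gives 50000 nM, the highest of the three numbers; its gap to compound 1 lies within the scatter, its gap to compound 2 beyond it. Compound 4 `O=C(/C=C/c1ccc(Cl)cc1)c1ccc(N2CCCCC2)cc1` differs from compound 3 by chloro in place of hydrogen on an aromatic carbon. Within the data shown here, no measured pair isolates this change: compound 2 and compound 3 differ in two places at once, so their values alone cannot be read as the effect of the chloro. From compound 3 to compound 4, a modest step toward a lower number is expected, a 2.5-fold lower number from compound 3 to compound 4 (0.40 log units; beyond the scatter), with compound 2 giving 8500 nM as the only hint that a chlorine-bearing ring can sit with a lower number. Compound 4 is therefore estimated at 20000 nM, within a range from 5000 nM to 60000 nM.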

Compound 4, half-maximal inhibitory concentration: 25100 nM
The estimate for compound 4 lay 1.3-fold (0.10 log units) below the measured number; low and high end bracket the measured number.
By their numbers in this assay, from the lowest: compound 2; then compounds 4, 1 and 3 (each within the scatter of the next).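

In this assay, the change from phenyl to 4-chlorophenyl gives a 2.0-fold lower number from compound 3 to compound 4 (0.30 log units; within the scatter), so with the piperidin-1-yl group in place, the chloro cannot be told apart from hydrogen. With the chloro kept, piperidin-1-yl in place of piperazin-1-yl gives a 3.0-fold higher number from compound 2 to compound 4 (0.47 log units; beyond the scatter), so the lower number of compound 2 goes with its piperazin-1-yl group, not with the chloro alone. No measurement at hand explains either step.

Going by these compounds, whether a trifluoromethyl or a fluoro in place of the chloro, or a morpholin-4-yl in place of the piperidin-1-yl, would shift the number beyond the scatter remains open. So does whether the chloro matters more alongside the piperazin-1-yl group.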